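Swapping Bromine for Nitro on a Shared Core

This account rests on a few compounds, and the source may have more. Where it says the series, first, only, none or still open, it means among the compounds named here.

Three compounds built on one shared core were tested in a functional assay on cells (Leukemia cell, Homo sapiens) for inhibition; a higher number here means a weaker inhibitor of growth, a lower number a stronger inhibitor of growth. Compound 1 `COc1ccc(-c2nc3sc(Cc4ccccc4)nn3c2SC#N)cc1` gives 3600 nM. Compound 2 `Clc1ccc(-c2cn3nc(Cc4ccccc4)sc3n2)cc1` gives 2100 nM. Compound 3 `O=Cc1c(-c2ccc(Br)cc2)nc2sc(Cc3ccccc3)nn12` gives 1410 nM, the lowest of the three numbers; its gap to compound 2 lies within the usual scatter, so those two cannot be ranked against each other, while its gap to compound 1 lies beyond the scatter.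

Compound 4 `O=Cc1c(-c2ccc([N+](=O)[O-])cc2)nc2sc(Cc3ccccc3)nn12` has not yet been measured. It differs from compound 3 in a single place: nitro in place of bromo on an aromatic carbon.

Among the compounds with values here, no two measured compounds differ in only one place, so there is no measured step of this kind to lean on, and the numbers so far cannot say how such a swap plays out. The expectation in this assay is therefore a small step, in either direction, or none beyond the scatter, with compound 3 as the anchor. The step from compound 3 to compound 4 is estimated as a 1.1-fold higher number from compound 3 to compound 4 (0.03 log units; within the scatter). Compound 4 is expected to give about 1500 nM, with a range from 500 nM to 4500 nM.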

Compound 4, concentration for 50% growth inhibition: 5900 nM
The estimate for compound 4 lay 3.9-fold (0.59 log units) below the measured number, and the stated range ends below it.
By their numbers in this assay, from the lowest: compounds 3, 2, 1 and 4 (each within the scatter of the next, the first and the last beyond it).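

In this assay, within the data shown here, nitro in place of bromo on an aromatic carbon gives a 4.2-fold higher number from compound 3 to compound 4 (0.62 log units; beyond the scatter) and provides the first reading of a change made in a single place on this core. The position para to a large group is therefore not indifferent to its substituent, since this swap weakens growth inhibition rather than leaving it unchanged. Nothing measured here speaks to why the number rises.

Compound 1 and compound 2 differ from compound 3 in more than one place, so they cannot show whether this step reflects the loss of bromo, the arrival of nitro, or both. Going by these compounds, how an amine, a carboxylic acid or a simple methyl group on the same carbon would compare with bromo and nitro remains open.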